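From carboxy to (3-methoxyazetidin-1-yl)carbonyl

The source may hold more compounds than are shown below. What is called first, only, known or untested is meant among the compounds shown, and "the series" means these compounds.

Compound 1 `CN1CCN(C(=O)/C=C/c2ccncc2-c2ccc3ccccc3c2)CC1`: > 10000 nM (a limit)
Compound 2 `CNC(=O)/C=C/c1ccncc1-c1ccc2ccccc2c1`: 8680 nM
Compound 3 `O=C(O)/C=C/c1ccncc1-c1ccc2ccccc2c1`: > 10000 nM (a limit)

All three values come from a functional assay on MDA-MB-231 cells (Homo sapiens) for inhibition, read by sulforhodamine B assay, with a stated time of 72 h; on this read-out lower numbers stand for stronger inhibition of growth and higher numbers for weaker inhibition of growth. In this assay compound 3 stands at > 10000 nM, which is a limit and not a number. That position is shared within the set, with the limit of > 10000 nM in this assay, at which 2 of the 3 values shown sit.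

Compound 4 `COC1CN(C(=O)/C=C/c2ccncc2-c2ccc3ccccc3c2)C1` carries 3-methoxyazetidin-1-yl in place of hydroxy on a carbonyl carbon, and the difference counts as 3-methoxyazetidin-1-yl in place of hydroxy on a carbonyl carbon.

Three measured exchanges on the same carbonyl carbon bear on this change. Methylamino in place of 4-methylpiperazin-1-yl gave an at least 1.1-fold lower number from compound 1 to compound 2 (0.06 log units; that floor lies within the scatter). Hydroxy in place of methylamino gave an at least 1.1-fold higher number from compound 2 to compound 3 (0.06 log units; that floor lies within the scatter). Hydroxy in place of 4-methylpiperazin-1-yl gave a step that the two limits leave unreadable from compound 1 to compound 3.

Within the data shown here, the only true number in the set is that of compound 2 at 8680 nM, and the steps that can be read stay within the scatter. No step beyond the scatter is therefore expected in this assay. The expected step is an at least 1.1-fold lower number from compound 3 to compound 4 (0.04 log units; that floor lies within the scatter). The estimate for compound 4 is 9000 nM, with an expected range from 4000 nM to 15000 nM.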

Compound 4, concentration for 50% growth inhibition: > 10000 nM
Compound 4 gave a limit, no number; the forecaster's own chance of this, stated with the estimate: 55%; middle value at least 1.1-fold (0.04 log units) away from the limit.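

Compound 4 gives > 10000 nM in this assay, which is a limit and not a number, so a ring-bearing amide with 3-methoxyazetidin-1-yl on this carbonyl carbon adds no second true number to the set. Putting 3-methoxyazetidin-1-yl in place of methylamino on the carbonyl carbon gives an at least 1.1-fold higher number from compound 2 to compound 4 (0.06 log units; that floor lies within the scatter), while the steps reaching compound 4 from the other two compounds cannot be read. Across the carboxy group and the three amides, no readable change at this position goes beyond the scatter, and the set now gathers at one ceiling: the limit of > 10000 nM in this assay, at which 3 of the 4 values shown sit.

The compounds shown leave open how far compound 1, compound 3 and compound 4 lie from one another, and whether any of them truly differs from compound 2. They also leave open whether another group on this carbonyl carbon, such as ethylamino, morpholin-4-yl or a longer chain on the amide nitrogen, would give a number clearly lower than that of compound 2 in this assay.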